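Urea series on the shared core: benzyl replaces aryl

The source may hold more compounds than are shown below. What is called first, only, known or untested is meant among the compounds shown, and "the series" means these compounds.

compound 1 `COC(=O)c1cc(=O)c2cc(NC(=O)Nc3ccc(Cl)c(Cl)c3)ccc2[nH]1` — > 6350 nM
compound 2 `COC(=O)c1cc(=O)c2cc(NC(=O)Nc3cccc(C(C)=O)c3)ccc2[nH]1` — > 8080 nM

The series is followed in a functional assay on UoC-B1 cells (Homo sapiens) for antiproliferative activity, with a stated time of 72 h; a lower number here means that less compound is needed, a higher number that more compound is needed for the effect. For compound 1, the value > 6350 nM is a limit of the assay and not a number. For compound 2, the value > 8080 nM is likewise a limit and not a number. Within the data shown here, the only measured step, a step that the two limits leave unreadable from compound 1 to compound 2, is therefore unreadable; the two entries the limit of > 6350 nM in this assay, at which 1 of the 2 values shown sits, and the limit of > 8080 nM in this assay, at which 1 of the 2 values shown sits, are both limits. Compound 2 thus stands at a limit, and no numbered value exists anywhere in the series beside it.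

Compound 3 is `COC(=O)c1cc(=O)c2cc(NC(=O)NCc3ccccc3)ccc2[nH]1`. The change from compound 2 is benzyl in place of 3-acetylphenyl on an amide-type nitrogen. Among the measured compounds shown here, no measured step bears on this change with a readable size, since the one step in hand is bounded by limits at both ends. The data give no direction beyond the scatter. The expected step is a step that the limit leaves unreadable from compound 2 to compound 3, which is taken as about none. Compound 3 is estimated at 15000 nM, with a range from 5000 nM to 50000 nM, and most likely the assay again reports only a limit.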

Compound 3, half-maximal effective concentration: > 19500 nM
Compound 3 gave a limit, no number (the forecaster's own chance of this, stated with the estimate: 75%); at least 1.3-fold (0.11 log units) between middle value and limit.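

In this assay compound 3 gives > 19500 nM, which is a limit and not a number. Among these compounds, compound 1 and compound 2 also stand at limits, so no step among compound 1, compound 2 and compound 3 can be read. As far as these compounds go, how benzyl, 3-acetylphenyl and 3,4-dichlorophenyl on the urea rank against one another in this assay remains open.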